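Amino in Place of Hydrogen: Expected Cytotoxicity of Compound 4

This account rests on a few compounds, and the source may have more. Where it says the series, first, only, none or still open, it means among the compounds named here.

Measured compounds:
compound 1 `OB1OCc2ccc(-n3cc(Sc4ccc(F)cc4)c4ccccc43)cc21` gives > 10 ug/mL
compound 2 `O=C(c1ccccc1)c1ccn(-c2ccc3c(c2)B(O)OC3)c1` gives > 10 ug/mL
compound 3 `COc1cc(C(=O)c2ccn(-c3ccc4c(c3)B(O)OC4)c2)cc(OC)c1OC` gives 1.15 ug/mL

Three compounds were tested in an ADME assay on L929 cells (Mus musculus) for cytotoxicity, read by resazurin assay, with a stated time of 72 h; on this read-out lower numbers stand for stronger inhibition and higher numbers for weaker inhibition. For compound 1 the result is a limit of the assay, > 10 ug/mL. For compound 2 the result is also a limit, > 10 ug/mL. Compound 3 gives a number, 1.15 ug/mL. Compound 2 therefore sits at the limit of > 10 ug/mL in this assay, at which 2 of the 3 values shown sit, so its true value is not known. Compound 4 `Nc1ccc(C(=O)c2ccn(-c3ccc4c(c3)B(O)OC4)c2)cc1` differs from compound 2 by amino in place of hydrogen on an aromatic carbon. Within the data shown here, no measured pair shows the amino group entering, so in this assay no step beyond the usual scatter is expected. Compound 4 is estimated at 12 ug/mL, with a range from 4 ug/mL to 40 ug/mL. That estimate means an expected step that the limit leaves unreadable from compound 2 to compound 4, and the result may again be a limit.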

Compound 4, half-maximal inhibitory concentration: 3.9 ug/mL
Compound 4: middle estimate off by 3.1-fold (0.49 log units), on the high side, and the stated range ends above it.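

In this assay, phenyl to 4-aminophenyl gives an at least 2.5-fold lower number from compound 2 to compound 4 (0.40 log units; beyond the scatter). Among these compounds, this is the first readable step, and it shows that a single amino group at this place on the aromatic ring can move the result beyond the usual scatter. The true step may be larger, as compound 2 has only a limit: the limit of > 10 ug/mL in this assay, at which 2 of the 4 values shown sit.

As far as these compounds go, it remains open whether this step is specific to the amino group or whether a hydroxyl group or a carboxylic acid on the same carbon would give a similar one.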